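Dichloroacetamide Biphenyls: Cytotoxicity Against KB 3-1 Cells

This account rests on a few compounds, and the source may have more. Where it says the series, first, only, none or still open, it means among the compounds named here.

Compound 1, `O=C(Nc1cccc(-c2cccc(NC(=O)C(Cl)Cl)c2)c1)C(Cl)Cl`, reaches only a limit: in a functional assay on KB 3-1 cells (Homo sapiens) for cytotoxicity, read by MTT assay, with a stated time of 68 h (a lower number here means a stronger inhibitor, a higher number a weaker inhibitor), compound 1 gives > 50000 nM. Compound 2, `O=C(Nc1cccc(-c2ccccc2Cl)c1)C(Cl)Cl`, likewise reaches only a limit, and in this assay compound 2 gives > 50000 nM.

Compound 2 thus stands at the limit of > 50000 nM in this assay, at which 2 of the 2 values shown sit, a limit and not a number. Compound 3, `O=C(Nc1cccc(-c2ccccc2)c1)C(Cl)Cl`, differs from compound 2 by hydrogen in place of chloro on an aromatic carbon. Among the compounds with values here, no step between measured compounds is known here, and the change is small. No step beyond the scatter is expected in this assay. Compound 3 is expected to give about 60000 nM, between 30000 nM and 200000 nM, most likely again only a limit. The estimated step that the limit leaves unreadable from compound 2 to compound 3 is expected to lie within the scatter.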

Compound 3, half-maximal inhibitory concentration: 46800 nM
Estimate against measurement, compound 3: 1.3-fold (0.11 log units) above, and the stated range covers the measured number.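

In this assay, compound 3 alone gives a number and not a limit, with hydrogen in place of chloro on an aromatic carbon ortho to a large group: an at least 1.0-fold lower number from compound 2 to compound 3 (0.02 log units; that floor lies within the scatter). Hydrogen in place of ((dichloromethyl)carbonyl)amino gives an at least 1.0-fold lower number from compound 1 to compound 3 (0.02 log units; that floor lies within the scatter), so neither change is shown to move the result beyond the scatter. The other two compounds remain limits: the limit of > 50000 nM in this assay, at which 2 of the 3 values shown sit.

From the compounds shown here alone, whether an amine or a carboxylic acid on this aromatic carbon would give a much lower number than compound 3 stays open.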